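A few compounds are considered here, and "the series" means these few. Any claim that something is new, unique, unknown or untested is made for them only; others in the source may bear on it.

Working notes on the series, read in a functional assay on MDA-MB-231 cells (Homo sapiens) for antiproliferative activity, read by MTT assay, with a stated time of 48 h; a higher number here means a weaker inhibitor, a lower number a stronger inhibitor. For the measured compounds named here, compound 1 (`COc1ccc(/C=C/C(=O)Nc2cc(Sc3ncn[nH]3)c(O)c3ccccc23)cc1OC`) gives 52500 nM, the only true number so far, so it has no measured neighbour to be ranked against. Compound 2 (`O=C(Nc1cc(Sc2ncnc3nc[nH]c23)c(O)c2ccccc12)c1ccc([N+](=O)[O-])cc1`) gives > 100000 nM, which is a limit of the assay and not a number. The next compound to be read is compound 3 (`O=C(/C=C/c1ccc(Cl)cc1)Nc1cc(Sc2ncn[nH]2)c(O)c2ccccc12`), which keeps the shared core and amide chain of compound 1 and changes one end group: 4-chlorophenyl in place of 3,4-dimethoxyphenyl on a double-bonded chain carbon bound to a double-bonded chain carbon. Going by the values given here, no measured pair isolates this exchange, so the size of the step rests on the reading of compound 1 at 52500 nM alone. In this assay the expected result is a 1.3-fold lower number from compound 1 to compound 3 (0.12 log units; within the scatter), an estimated step that stays within the usual scatter, with no firm direction. For compound 3 the estimated value is 40000 nM, with an expected range of 15000 nM to 100000 nM.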

Compound 3, half-maximal inhibitory concentration: > 100000 nM
Compound 3: a limit, no number; the forecaster's own chance of this, stated with the estimate: 20%; middle value at least 2.5-fold (0.39 log units) from the limit.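

In this assay, 4-chlorophenyl in place of 3,4-dimethoxyphenyl on a double-bonded chain carbon bound to a double-bonded chain carbon gives an at least 1.9-fold higher number from compound 1 to compound 3 (0.27 log units; that floor lies within the scatter). For the compounds shown here, this is the first step that can be read at this place, but compound 3 gives a limit and not a number, so the step has a floor and no measured size, and that floor stays within the scatter. Compound 1 therefore remains the only true number in the series, and the other readings stop at one limit: the limit of > 100000 nM in this assay, at which 2 of the 3 values shown sit.

On these data alone, whether the exchange moves the reading beyond the scatter stays open, and so does the share of each methoxy group in the reading of compound 1. A 4-methoxyphenyl or a 4-aminophenyl at this place would address what these compounds leave unresolved.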